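The source may report more compounds than this note shows. Statements on the series, on what has been measured and on what is new or still open speak of the compounds shown alone.

Compound 1 `O=S(=O)(c1ccc2c(c1)C1CNCC2C1)N1CCCC1` gives 3.1 nM in an assay on HEK293 cells for binding affinity to Neuronal acetylcholine receptor; alpha4/beta2 (Homo sapiens); on this read-out higher numbers stand for weaker inhibition and lower numbers for stronger inhibition. Compound 2 `CC(=O)c1ccc2c(c1)C1CNCC2C1` gives 0.17 nM. Compound 3 `c1ccc(-n2cnc3cc4c(cc32)C2CNCC4C2)cc1` gives 0.14 nM.

On these numbers compound 2 stands second highest of the three. Its nearest neighbour is compound 3, whose number is lower by a gap that sits within the scatter, so the two cannot be told apart. Its furthest neighbour is compound 1, whose number is higher by a gap well beyond the scatter.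

Compound 4 `Nc1ccc2c(c1)C1CNCC2C1` has not yet been measured. It differs from compound 2 by amino in place of acetyl on an aromatic carbon. Within the data shown here, no measured pair shows this change, so the size of its step is not known from the data. Compound 4 is expected to give 0.8 nM in this assay, within 0.2 nM to 4 nM. That estimate means a step of a 4.7-fold higher number from compound 2 to compound 4 (0.67 log units; beyond the scatter), a modest move toward a higher number that may not exceed the scatter.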

Compound 4, inhibition constant: 100 nM
Beside the measured number, compound 4's estimate is 130-fold (2.10 log units) below it; the whole stated range lies below it.
By their numbers in this assay, from the lowest: compounds 3 and 2 (each within the scatter of the next); then compound 1; then compound 4.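

In this assay, amino in place of acetyl on this aromatic carbon brings a 590-fold higher number from compound 2 to compound 4 (2.77 log units; beyond the scatter), showing that this position is highly sensitive to the group it carries. Among these compounds, the earlier compounds offered no single change to read, and this step is the first to isolate one. The data offer no explanation for its size.

Still open, from the compounds shown here alone, is whether the step follows from losing acetyl or from gaining amino. A methyl group, a nitrile or an acetamide on the same carbon could help separate the two.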